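A few compounds are considered here, and "the series" means these few. Any claim that something is new, unique, unknown or untested is made for them only; others in the source may bear on it.

Compound 2 `COc1ccc2[nH]c(-c3ccc[nH]3)c(C3CC(=O)NC3=O)c2c1` gives 6000 nM in a functional assay on Hs 683 cells (Homo sapiens) for cytotoxicity, read by MTT assay, with a stated time of 72 h (on this read-out lower numbers stand for stronger inhibition and higher numbers for weaker inhibition), the lowest of the three numbers in hand. Compound 1 `Cc1ccc2[nH]c(-c3ccc[nH]3)c(C3CC(=O)NC3=O)c2c1` gives 8000 nM; the step of a 1.3-fold lower number from compound 1 to compound 2 (0.12 log units; within the scatter) is within the scatter, so the two stand together. Compound 3 `COc1ccc2[nH]c3c(c4c(n5cccc35)C(=O)N(C)C4=O)c2c1` gives 72000 nM, a number well beyond the scatter from compound 2. Compound 4 `COc1ccc2[nH]c(-c3ccc[nH]3)cc2c1` differs from compound 2 by hydrogen in place of 2,5-dioxopyrrolidin-3-yl on an aromatic carbon. For the measured compounds named here, no measured step concerns this part of the structure: the one measured step concerns a substituent on another ring, and compound 3 differs in several places at once. With the group removed entirely, the expectation for compound 4 is a weaker result, a 5.0-fold higher number from compound 2 to compound 4 (0.70 log units; beyond the scatter), with wide uncertainty. Compound 4 is estimated at 30000 nM, between 8000 nM and 110000 nM.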

Compound 4, half-maximal inhibitory concentration: 50000 nM
Estimate against measurement, compound 4: 1.7-fold (0.22 log units) below; measured number inside the range.
By their numbers in this assay, from the lowest: compounds 2 and 1 (each within the scatter of the next); then compounds 4 and 3 (each within the scatter of the next).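

For the compounds shown here, replacing 2,5-dioxopyrrolidin-3-yl with hydrogen gives the first reading at this aromatic carbon: in this assay the change produces an 8.3-fold higher number from compound 2 to compound 4 (0.92 log units; beyond the scatter) and so, unlike the methoxy for methyl change on the other ring, it moves the number clearly. The result ties the lower number of compound 2 to the presence of this group, though nothing at hand explains the link. Still open, as far as these compounds go, is whether the intact ring is required, or whether a carboxylic acid, a primary amide or an amine on this carbon would serve equally.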